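Methoxy for Chloro on a Weakly Cytotoxic Hydrazone

The source may report more compounds than this note shows. Statements on the series, on what has been measured and on what is new or still open speak of the compounds shown alone.

Compound 3, with the structure `Cn1cc(C(=O)N/N=C\c2cn(Cc3ccc(Cl)cc3)c3cc(F)ccc23)c2ccccc21`, is the weakest of the three compounds measured in a functional assay on DU-145 cells (Homo sapiens) for cytotoxicity (on this read-out lower numbers stand for stronger inhibition and higher numbers for weaker inhibition), where compound 3 gives 84200 nM. Compound 1, with the structure `O=C(N/N=C\c1cn(Cc2ccc(Cl)cc2)c2cc(F)ccc12)c1c[nH]c2ccccc12`, gives 18600 nM, and compound 2, with the structure `COc1ccc(Cn2cc(/C=N\NC(=O)c3c[nH]c4ccccc34)c3ccccc32)cc1`, gives 43900 nM. Within the data shown here, the one single-point step among them, a 4.5-fold higher number from compound 1 to compound 3 (0.66 log units; beyond the scatter), shows that adding a methyl on an aromatic nitrogen weakened inhibition. Compound 4, with the structure `COc1ccc(Cn2cc(/C=N\NC(=O)c3cn(C)c4ccccc34)c3ccc(F)cc32)cc1`, keeps that methyl and differs from compound 3 in one place: methoxy in place of chloro on an aromatic carbon. Among the measured compounds shown here, no measured pair isolates this swap; compounds 1 and 2 differ from each other in more than one place, so their values alone cannot be assigned to the methoxy. Compound 3 already sits at the weak end of the range, and compound 2 shows that a methoxy-bearing compound can also be weak. The expected step for compound 4 in this assay is therefore a 1.1-fold lower number from compound 3 to compound 4 (0.02 log units; within the scatter), a change not beyond the scatter. Compound 4 is estimated at 80000 nM, with a range from 30000 nM to 200000 nM.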

Compound 4, half-maximal inhibitory concentration: 15200 nM
Compound 4: middle estimate off by 5.3-fold (0.72 log units), on the high side; the whole stated range lies above it.
By their numbers in this assay, from the lowest: compounds 4 and 1 (each within the scatter of the next); then compounds 2 and 3 (each within the scatter of the next).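

Among these compounds, this pair gives the first direct reading of the change from 4-chlorobenzyl to 4-methoxybenzyl, and in this assay it brings a 5.5-fold lower number from compound 3 to compound 4 (0.74 log units; beyond the scatter) and so stronger inhibition. The value of compound 2 could not show what the methoxy contributes, whereas this step shows that at this place, para to a large group, methoxy gives stronger inhibition than chloro when the methyl on the aromatic nitrogen is present. Nothing in the data explains why the swap has this effect.

Going by these compounds, whether the same swap gives a similar step with hydrogen on that aromatic nitrogen remains open. Also open, on these data alone, is how other groups at this place, such as an amine, a carboxylic acid or a longer chain, would compare with methoxy.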